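Changing the Aryl Group on a Growth Inhibitor

The source may report more compounds than this note shows. Statements on the series, on what has been measured and on what is new or still open speak of the compounds shown alone.

In a functional assay on MCF7 cells (Homo sapiens) for inhibition, read by CCK-8 assay, with a stated time of 48 h (on this read-out higher numbers stand for weaker inhibition of growth and lower numbers for stronger inhibition of growth), compound 1 (`CN1CCN(c2ccc(Nc3ncc(Cl)c(NCc4ccc(F)cc4)n3)nc2)CC1`) gives 19300 nM, while compound 2 (`CCc1ccc(Nc2nc(Nc3ccc(N4CCN(C)CC4)cn3)ncc2Cl)cc1`) gives 8230 nM, the lower of the two numbers. Compound 3 (`Cc1cc(C)c(Nc2nc(Nc3ccc(N4CCN(C)CC4)cn3)ncc2Cl)c(C)c1`) has 2,4,6-trimethylphenyl in place of 4-ethylphenyl on a nitrogen on an aromatic ring. Among the compounds with values here, only one measured step bears on this change: a 2.3-fold lower number from compound 1 to compound 2 (0.37 log units; beyond the scatter), a modest step seen with 4-ethylphenyl in place of 4-fluorobenzyl at that same place. The expected step, a 1.2-fold higher number from compound 2 to compound 3 (0.08 log units; within the scatter), is therefore small and stays within the scatter. Compound 3 is estimated at 10000 nM, with an expected range from 4000 nM to 25000 nM.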

Compound 3, concentration for 50% growth inhibition: 9470 nM
Compound 3: the middle estimate sits 1.1-fold (0.02 log units) above what was measured, within the range that was stated.
By their numbers in this assay, from the lowest: compounds 2 and 3 (each within the scatter of the next); then compound 1.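

In this assay, swapping 4-ethylphenyl for 2,4,6-trimethylphenyl on this nitrogen gives a 1.2-fold higher number from compound 2 to compound 3 (0.06 log units; within the scatter), so the two groups cannot be told apart here. Replacing 4-fluorobenzyl with 2,4,6-trimethylphenyl gives a 2.0-fold lower number from compound 1 to compound 3 (0.31 log units; beyond the scatter), so this second phenyl group also gives a lower number than the 4-fluorobenzyl group. No evidence is available to explain these numbers. Still open, going by these compounds, is whether a group carrying an amine or a carboxylic acid at this place, rather than the carbon-only rings seen so far, would shift the number beyond the scatter.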